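A few compounds are considered here, and "the series" means these few. Any claim that something is new, unique, unknown or untested is made for them only; others in the source may bear on it.

Working notes on the series. Compound 1 `N#C/N=C(/NCCCc1c[nH]cn1)NCCCC1CCCCC1` in an in vitro functional assay on Sf9 cells for antagonist activity at histamine H2 receptor (Homo sapiens) (on this read-out higher numbers stand for higher potency (the scale is a negative logarithm) and lower numbers for lower potency), gives only a limit in both of its entries, namely < 5; < 5 (2 entries). Compound 2 `N#C/N=C(/NCCCCc1c[nH]cn1)NCCCC1CCCCC1` in this assay likewise gives only a limit, < 5; compound 2 therefore stands at the limit of < 5 in this assay, at which 1 of the 3 values shown sits, and no single number is known for it. Compound 3 `N#C/N=C(/NCCCCc1c[nH]cn1)NCCCc1ccc(F)cc1` in this assay gives 5.28. Within the data shown here, the one measured step, a number at least 0.28 log units higher from compound 2 to compound 3 (that floor lies within the scatter), starts from a limit, and its floor lies within the scatter, so it fixes neither size nor direction firmly. Compound 4 `CN/C(=N\C#N)NCCCCc1c[nH]cn1` differs from compound 2 by hydrogen in place of 2-cyclohexylethyl on a saturated chain carbon bound to an amine nitrogen. Among the measured compounds shown here, no measured step removes the whole group in this way, so the expectation rests on little. For compound 4 the step of a number at least 0.30 log units higher from compound 2 to compound 4 (that floor lies within the scatter) is expected. Compound 4 is estimated at 5.3, with a range from 4.6 to 6.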

Compound 4, negative logarithm of the antagonist equilibrium constant: < 5
Compound 4 gave a limit, no number; the forecaster's own chance of this, stated with the estimate: 35%; middle value at least 0.30 log units away from the limit.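

Compound 4, like compound 2, gives only a limit, so no step between the two can be read: the limit of < 5 in this assay, at which 2 of the 4 values shown sit.

The compounds shown leave open whether hydrogen in place of 2-cyclohexylethyl shifts the read-out in either direction, and by how much.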